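A few compounds are considered here, and "the series" means these few. Any claim that something is new, unique, unknown or untested is made for them only; others in the source may bear on it.

Working notes on the series. In an ADME assay on GES1 cells (Homo sapiens) for inhibition, read by MTT assay, with a stated time of 72 h (on this read-out lower numbers stand for stronger inhibition and higher numbers for weaker inhibition), compound 1 (`Cc1cc(Nc2cc(-c3ccccc3)[nH]n2)n2nc(SCc3c(Cl)cccc3Cl)nc2n1`) reads 39600 nM while compound 2 (`Cc1cc(Nc2cc(-c3ccccc3)[nH]n2)n2nc(SCc3ccc([N+](=O)[O-])cc3)nc2n1`) reads 43600 nM and compound 3 (`Cc1cc(Nc2cc(-c3ccccc3)[nH]n2)n2nc(SCc3ccccc3Br)nc2n1`) reads 41100 nM on the same shared core. Compound 3 therefore cannot be separated from the other two, as a 1.0-fold higher number from compound 1 to compound 3 (0.02 log units; within the scatter) and a 1.1-fold lower number from compound 2 to compound 3 (0.03 log units; within the scatter) both show.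

The next member is compound 4 (`Cc1ccc(CSc2nc3nc(C)cc(Nc4cc(-c5ccccc5)[nH]n4)n3n2)cc1`), which has 4-methylphenyl in place of 2-bromophenyl on a saturated chain carbon bound to a sulfur and is otherwise unchanged.

The two steps to compound 3 bear on this swap, together with a 1.1-fold higher number from compound 1 to compound 2 (0.04 log units; within the scatter) as the third exchange at the same place. All three lie within the scatter, even though the groups exchanged differ in their substituents. Going by the values given here, no measured compound carries a methyl group on this ring, so the new group itself is untested. With that caveat, the expected step is a 1.0-fold lower number from compound 3 to compound 4 (0.00 log units; within the scatter) and no change beyond the scatter is expected in either direction. In this assay compound 4 is estimated at 41000 nM within an expected range of 27000 nM to 62000 nM for repeated readings.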

Compound 4, half-maximal inhibitory concentration: 36200 nM
The estimate for compound 4 lay 1.1-fold (0.05 log units) above the measured number, and the stated range covers the measured number.
By their numbers in this assay, from the lowest: compounds 4, 1, 3 and 2 (each within the scatter of the next).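

In this assay, the 4-methylphenyl group on a saturated chain carbon bound to a sulfur does not separate compound 4 from any earlier compound (a 1.1-fold lower number from compound 3 to compound 4 (0.06 log units; within the scatter); a 1.2-fold lower number from compound 2 to compound 4 (0.08 log units; within the scatter); a 1.1-fold lower number from compound 1 to compound 4 (0.04 log units; within the scatter)). The flat picture at this position therefore now extends to a ring bearing a methyl group, alongside the 2,6-dichlorophenyl, 4-nitrophenyl and 2-bromophenyl rings, and the exchange of 2-bromophenyl for 4-methylphenyl, which swaps a bromine-bearing ring for a carbon-only one, leaves the reading within the scatter. No measurement is at hand that could explain why these four compounds read alike.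

As far as these compounds go, all four compounds carry a substituted phenyl ring on the same one-carbon link to the sulfur, so it remains open whether an amine, a carboxylic acid or a longer chain at this position would also stay within the scatter. The series shown also leaves open whether this flat behaviour holds when the methyl group or the phenyl group elsewhere on the shared core is exchanged.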